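Stretching an ethyl chain to butyl in compound 4

This account rests on a few compounds, and the source may have more. Where it says the series, first, only, none or still open, it means among the compounds named here.

In a physicochemical assay for lipophilicity (on this read-out higher numbers stand for higher lipophilicity and lower numbers for lower lipophilicity), compound 3 `CCN(C1=NCCN1)c1c(Br)cccc1Br` gives -1.01 and compound 1 `Brc1cccc(Br)c1N(CC1CC1)C1=NCCN1` gives -1.12 which is the same within the scatter. Measured against these two, compound 2 `Brc1ccc(N(CC2CC2)C2=NCCN2)c(Br)c1` stands clearly higher at -0.31 on the same scale.

The next compound is compound 4 `CCCCN(C1=NCCN1)c1c(Br)cccc1Br` which carries butyl where compound 3 carries ethyl. The difference is ethyl in place of hydrogen on a saturated chain carbon, two bonds along the chain from a nitrogen on an aromatic ring with ethyl in place of hydrogen on a saturated chain carbon, two bonds along the chain from a nitrogen on an aromatic ring.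

Going by the values given here, only one measured step bears on this change. It is a number 0.11 log units higher from compound 1 to compound 3 (within the scatter) with methyl in place of cyclopropyl on a saturated chain carbon bound to a nitrogen on an aromatic ring. Going by the size of a number 0.11 log units higher from compound 1 to compound 3 (within the scatter) no large jump is expected from the longer chain, although no open chain beyond ethyl has been measured yet. The expected change is a number 0.31 log units higher from compound 3 to compound 4 (beyond the scatter) which would be a modest rise. For compound 4 the estimated value in this assay is -0.7 with an expected range from -1.1 to -0.2 as the likely span.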

Compound 4, distribution coefficient: -2.5
The estimate for compound 4 lay 1.80 log units above the measured number, and the stated range ends above it.
By their numbers in this assay, from the lowest: compound 4; then compounds 1 and 3 (each within the scatter of the next); then compound 2.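

Ethyl in place of hydrogen on a saturated chain carbon, two bonds along the chain from a nitrogen on an aromatic ring, turning ethyl into butyl, gives a number 1.49 log units lower from compound 3 to compound 4 (beyond the scatter) in this assay. Read from the other side, replacing cyclopropyl with propyl gives a number 1.38 log units lower from compound 1 to compound 4 (beyond the scatter), whereas methyl in place of cyclopropyl at that same place gave only a number 0.11 log units higher from compound 1 to compound 3 (within the scatter), so this place is not indifferent to every change, and here adding carbon goes with a lower number rather than a higher one. Nothing available explains this large fall.

Going by these compounds, with only ethyl and butyl among the open chains, it remains open whether the number falls step by step along the chain or drops suddenly, and a pentyl chain or a chain ending in an amine would help to tell these apart. On these data alone, it also remains open whether butyl would bring a fall of similar size on the core of compound 2, which stands at a clearly higher number than compound 1.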